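The source may report more compounds than this note shows. Statements on the series, on what has been measured and on what is new or still open speak of the compounds shown alone.

Compound 1 `Cc1cccc(Cn2nc(Cl)c3c(NC(=O)c4csc5c(N)ncnc45)cccc32)n1` gives 8 nM
Compound 2 `Cc1cccc(Cn2nc(I)c3c(NC(=O)c4csc5c(N)ncnc45)cccc32)n1` gives 30 nM
Compound 3 `Cc1cccc(Cn2nc(C)c3c(NC(=O)c4csc5c(N)ncnc45)cccc32)n1` gives 80 nM

All three numbers come from a functional assay on NFS-60 cells (Mus musculus) for inhibition, with a stated time of 72 h; a higher number here means a weaker inhibitor of growth, a lower number a stronger inhibitor of growth. Compound 3 has the highest number of the three, so it is the weakest inhibitor among them, although its gap to compound 2 is modest. Compound 4 `CCc1nn(Cc2cccc(C)n2)c2cccc(NC(=O)c3csc4c(N)ncnc34)c12` is compound 3 with one small addition: methyl in place of hydrogen on a saturated chain carbon bound to an aromatic carbon. This turns the methyl into an ethyl.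

Going by the values given here, no measured pair shows this exact change, so the evidence is indirect. Changing the group at this one place has already moved the number: a 3.8-fold higher number from compound 1 to compound 2 (0.57 log units; beyond the scatter), a 10-fold higher number from compound 1 to compound 3 (1.00 log units; beyond the scatter) and a 2.7-fold higher number from compound 2 to compound 3 (0.43 log units; beyond the scatter). All three steps are modest but beyond the scatter. They swap one group for a different kind of group, whereas methyl to ethyl only lengthens a chain, so a smaller step seems likely. The expected step is a 1.5-fold higher number from compound 3 to compound 4 (0.18 log units; within the scatter), slightly upward and within the scatter. For compound 4 the estimated value is 120 nM, with an expected range of 40 nM to 350 nM.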

Compound 4, concentration for 50% growth inhibition: > 10000 nM
Compound 4 ended at the assay's limit; the forecaster's own chance of this, stated with the estimate: 2%; at least 83-fold (1.92 log units) between middle value and limit.
By their numbers in this assay, from the lowest: compound 1; then compound 2; then compound 3. At a limit, above all of these: compound 4.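

Compound 4 gives a limit of the assay rather than a number: the limit of > 10000 nM in this assay, at which 1 of the 4 values shown sits.

Turning the methyl into an ethyl at this place produces an at least 120-fold higher number from compound 3 to compound 4 (2.09 log units; beyond the scatter), a large step where every change among the earlier compounds was modest. The same jump appears against the two halogen compounds, with an at least 330-fold higher number from compound 2 to compound 4 (2.52 log units; beyond the scatter) and an at least 1200-fold higher number from compound 1 to compound 4 (3.09 log units; beyond the scatter), so chloro, iodo and methyl all give a measured number in this assay, while ethyl does not reach a measurable value.

The compounds shown cannot say why the addition of one methyl has so sharp an effect here. On these data alone, it also remains open whether a methoxy, an amine or a nitrile at this place would keep the growth inhibition, or whether a longer chain would behave like ethyl.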